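The source may hold more compounds than are shown below. What is called first, only, known or untested is meant among the compounds shown, and "the series" means these compounds.

Compounds measured in a functional assay on HEK293 cells for antagonist activity at thromboxane A2 receptor (Homo sapiens), read by fluorescence and calcium flux (a higher number here means a weaker inhibitor, a lower number a stronger inhibitor), so far:

- compound 1, `Cc1cccc(Oc2ccc(C#N)cc2S(=O)(=O)NC(=O)NC(C)C)c1`: 1690 nM
- compound 2, `CC(C)NC(=O)NS(=O)(=O)c1cc(C#N)ccc1Oc1ccc(F)cc1`: 9300 nM
- compound 3, `CC(C)NC(=O)NS(=O)(=O)c1cc(C#N)ccc1Oc1ccc(Br)cc1`: 9130 nM

Compound 3 stands second highest of the three numbers, its nearest neighbour being compound 2 (the pair differ by a 1.0-fold lower number from compound 2 to compound 3 (0.01 log units; within the scatter), within the scatter), and its furthest compound 1, which lies a 5.4-fold higher number from compound 1 to compound 3 (0.73 log units; beyond the scatter) away.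

Compound 4, `Cc1cccc(Nc2ccc(C#N)cc2S(=O)(=O)NC(=O)NC(C)C)c1`, differs from compound 3 in one place: (3-methylphenyl)amino in place of 4-bromophenoxy on an aromatic carbon. The change bundles two things. The first, the swap of the aryl substituent, has a measured counterpart: a 5.4-fold higher number from compound 1 to compound 3 (0.73 log units; beyond the scatter) and a 5.5-fold higher number from compound 1 to compound 2 (0.74 log units; beyond the scatter) both show that the 3-methylphenyl ether gives a clearly lower number than the 4-halophenyl ethers, and the halogens themselves are indistinguishable. Among the compounds with values here, the second, the oxygen linker becoming an amino linker, has no measured counterpart, so its contribution is unknown and widens the range.

On balance compound 4 is expected to land near compound 1, which means a 4.6-fold lower number from compound 3 to compound 4 (0.66 log units; beyond the scatter) in this assay, the direction set by the return to the 3-methylphenyl substituent seen in compound 1. The estimate for compound 4 in this assay is 2000 nM, with a range of 400 nM to 10000 nM.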

Compound 4, half-maximal inhibitory concentration: 9110 nM
For compound 4 the middle estimate is 4.6-fold (0.66 log units) below the measured one; measured number inside the range.
By their numbers in this assay, from the lowest: compound 1; then compounds 4, 3 and 2 (each within the scatter of the next).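

Within the data shown here, with the 3-methylphenyl group held constant, a 5.4-fold higher number from compound 1 to compound 4 (0.73 log units; beyond the scatter) in this assay gives the first direct reading of the linker at this aromatic carbon, and the amino linker does not keep the lower number seen with the oxygen linker. Compound 4 also shows no separation from the 4-halophenyl ethers, with a 1.0-fold lower number from compound 3 to compound 4 (0.00 log units; within the scatter) and a 1.0-fold lower number from compound 2 to compound 4 (0.01 log units; within the scatter), so the 3-methylphenyl group alone does not secure the lower number; among the four compounds, only the 3-methylphenyl group joined through oxygen, in compound 1, stands apart from the rest. No measured evidence bears on the reason for this linker result.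

Going by these compounds, the series gives one linker comparison, so it remains open whether an amino linker would leave the number unchanged with a 4-fluorophenyl or 4-bromophenyl group, or whether the result is specific to 3-methylphenyl. Also open, on these data alone, is how other linkers at this position, such as sulfur, methylene or a methyl-substituted amino group, would compare with oxygen when carrying the same 3-methylphenyl group on the shared core.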